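The source may hold more compounds than are shown below. What is called first, only, known or untested is meant among the compounds shown, and "the series" means these compounds.

Measured so far in a functional assay on HCT-15 cells (Homo sapiens) for inhibition, read by sulforhodamine B assay (a lower number here means a stronger inhibitor of growth, a higher number a weaker inhibitor of growth), with these results
compound 1 `CC(=O)Nc1ccc(CN2CCC=C(CCC(=O)NO)C2=O)cc1` gives "not determined" (no result reported) as its entry
compound 2 `O=C(CCC1=CCCN(Cc2ccc(NC(=O)c3ccccc3)cc2)C1=O)NO` gives > 10000 nM as its entry

Compound 2 stands at > 10000 nM in this assay, which is a limit of the assay and not a number. Within the data shown here, compound 1 offers no number for comparison, so the series holds no measured step to size the next change.

Compound 3 `O=C(CCC1=CCCN(Cc2ccc([N+](=O)[O-])cc2)C1=O)NO` differs from compound 2 as follows: nitro in place of benzamido on an aromatic carbon. In short, compound 3 carries nitro where compound 2 carries benzamido. Among the measured compounds shown here, with no measured step as a guide, no step beyond the scatter is expected in this assay, and no direction is favoured. The expected step of a number no higher from compound 2 to compound 3 (the limit leaves the size open) is read against a limit, not against a number. For compound 3 the estimate is 10000 nM, with an expected range from 3000 nM to 30000 nM at its upper end.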

Compound 3, concentration for 50% growth inhibition: > 10000 nM
Compound 3: only a limit was reported (the forecaster's own chance of this, stated with the estimate: 60%); the middle value lies on the limit itself.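

No step can be read between compound 2 and compound 3 in this assay because each carries only a limit of the assay: the limit of > 10000 nM in this assay, at which 2 of the 3 values shown sit.

Still open, from the compounds shown here alone, is whether nitro in place of benzamido on the aromatic carbon changes growth inhibition at all, and by how much.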